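The compounds below may be only part of what the source reports. "The series", "measured", "known", "first", "only" and "open" are said of these compounds alone.

Measured so far in an ADME assay on BJ cells (Homo sapiens) for cytotoxicity, with a stated time of 72 h; a higher number here means that more compound is needed for the effect, a lower number that less compound is needed:

compound 1 `C=C[C@@](C)(/C=C/c1ccc(O)cc1)CC/C=C/C(=O)OCC`: > 36600 nM, a limit of the assay.
compound 2 `C=C[C@@](C)(/C=C/c1ccc(O)cc1)CC/C=C/C#N`: > 36600 nM, a limit of the assay.
compound 3 `C=C[C@@](C)(/C=C/c1ccc(O)c(/C=C/C#N)c1)CCC=C(C)C`: > 36600 nM, a limit of the assay.

None of the three values is a number; each is a limit, and all three sit at the limit of > 36600 nM in this assay, at which 3 of the 3 values shown sit. Compound 2 and compound 1 differ in one place, by ethoxycarbonyl in place of cyano on a double-bonded chain carbon bound to a double-bonded chain carbon. The step that this change made, a step that the two limits leave unreadable from compound 2 to compound 1, cannot be read, since both ends are limits. Compound 3 carries the same kind of side chain as compound 2, but the difference between the two cores is not broken down here; compound 3, too, gives only a limit in this assay.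

Compound 4 `C=C[C@@](C)(/C=C/c1ccc(O)c(/C=C/C(=O)OCC)c1)CCC=C(C)C` has not been measured. Against compound 3 it differs by ethoxycarbonyl in place of cyano on a double-bonded chain carbon bound to a double-bonded chain carbon. The place of this change is, word for word, the same as for the change from compound 2 to compound 1, so it is the same change made on the core of compound 3.

With the measured pair unreadable, the expectation for compound 4 rests on where compound 3 stands. Because the limit of > 36600 nM in this assay, at which 3 of the 3 values shown sit, holds compound 3 as well as both members of the matched pair, compound 4 is expected to remain at the limit, and the expected step is a step that the limit leaves unreadable from compound 3 to compound 4. Compound 4 is expected at 50000 nM in this assay, with a likely range from 20000 nM to 150000 nM, and most probably reported again only as a limit rather than as a number.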

Compound 4, half-maximal effective concentration: > 36600 nM
Compound 4 gave a limit, no number (the forecaster's own chance of this, stated with the estimate: 90%); the middle value lies beyond the limit too.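

In this assay compound 4 gives > 36600 nM, a limit and not a number. No new step can be read between compound 3 and compound 4, since both ends are limits: the limit of > 36600 nM in this assay, at which 4 of the 4 values shown sit.

The compounds shown leave open at what concentration any of them would reach the half-maximal effect, and whether ethoxycarbonyl in place of cyano changes that concentration on either core.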